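Aminomethylpyridine in place of cyanofluorophenyl on the thiazole acid

The source may report more compounds than this note shows. Statements on the series, on what has been measured and on what is new or still open speak of the compounds shown alone.

Measured so far:
compound 1, `COc1ccc(C(c2ccccc2)c2nc(-c3ccc(Cl)cc3)c(CC(=O)O)s2)cc1`: 76 nM
compound 2, `O=C(O)Cc1sc(C(c2ccccc2)c2ccccc2)nc1-c1ccc(C(F)(F)F)cc1`: > 100000 nM, a limit of the assay and not a number
compound 3, `N#Cc1cc(-c2nc(C(c3ccc(F)cc3)c3ccc(F)cc3)sc2CC(=O)O)ccc1F`: 520 nM

In an in vitro functional assay on HEK285-7 cells for antagonist activity at prostaglandin D2 receptor 2 (Homo sapiens), read by BRET and beta-arrestin recruitment (a lower number here means a stronger inhibitor, a higher number a weaker inhibitor), compound 1 gives 76 nM. Compound 3 gives 520 nM. For compound 2 the assay reports only a limit, > 100000 nM. Among the two numbers shown, compound 3 holds the higher one; compound 1 sits at a lower number, and that gap lies beyond the scatter of repeated measurements.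

Compound 4, `Cc1cc(-c2nc(C(c3ccc(F)cc3)c3ccc(F)cc3)sc2CC(=O)O)cnc1N`, has not yet been measured. It differs from compound 3 in one place: 6-amino-5-methylpyridin-3-yl in place of 3-cyano-4-fluorophenyl on an aromatic carbon. Among the measured compounds shown here, no pair of measured compounds separated by a single change is available, so the exchange has no measured precedent here.

The step from compound 3 to compound 4 in this assay is expected to go toward a higher number, and to lie beyond the scatter, as a 2.9-fold higher number from compound 3 to compound 4 (0.46 log units; beyond the scatter). Compound 4 is therefore estimated at 1500 nM, with a range from 300 nM to 8000 nM.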

Compound 4, half-maximal inhibitory concentration: > 100000 nM
Compound 4: only a limit was reported (the forecaster's own chance of this, stated with the estimate: 10%); middle value at least 66-fold (1.82 log units) away from the limit.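

This is the first change in one place among the compounds shown, and with the rest of the molecule unchanged, it shows that the group on the aromatic carbon next to the ring nitrogen can decide whether this assay gives a number at all. Putting 6-amino-5-methylpyridin-3-yl in place of 3-cyano-4-fluorophenyl gives an at least 190-fold higher number from compound 3 to compound 4 (2.28 log units; beyond the scatter). Compound 4 reaches only > 100000 nM, a limit of the assay and not a number, and that limit recurs in the set: the limit of > 100000 nM in this assay, at which 2 of the 4 values shown sit.

The compounds shown do not separate the parts of this exchange: the pyridine ring nitrogen, the amine, the methyl, the nitrile and the fluorine all change at once. A pyridine without the amine, or a phenyl ring carrying an amine, would be needed to tell which part accounts for the step.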